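The compounds below may be only part of what the source reports. "The series", "measured", "known", "first", "only" and "open" are said of these compounds alone.

Compound 2 `CCCc1nnc(SCc2ccccc2Cl)n1N1C(=O)c2ccccc2C1=O` stands only on a limit: in a functional assay on HepG2 cells (Homo sapiens) for cytotoxicity, read by MTT assay, with a stated time of 48 h (on this read-out higher numbers stand for weaker inhibition and lower numbers for stronger inhibition), compound 2 gives > 200000 nM, a limit of the assay rather than a number. Compound 1 `C#CCSc1nnc(CCC)n1N1C(=O)c2ccccc2C1=O` likewise reaches only a limit, giving > 200000 nM in this assay. The single step among these values, a step that the two limits leave unreadable from compound 1 to compound 2, is therefore not readable, as the limit of > 200000 nM in this assay, at which 2 of the 2 values shown sit, shows. Compound 3 `CCCc1nnc(SC)n1N1C(=O)c2ccccc2C1=O` differs from compound 2 by hydrogen in place of 2-chlorophenyl on a saturated chain carbon bound to a sulfur. With no readable step to lean on, no change beyond the scatter is expected in this assay, and another limit is the likelier outcome. Compound 3 is estimated at 200000 nM, between 50000 nM and 1000000 nM. The step this estimate means, a number no higher from compound 2 to compound 3 (the limit leaves the size open), is expected to stay within the scatter.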

Compound 3, half-maximal inhibitory concentration: > 200000 nM
Compound 3 was reported as a limit (the forecaster's own chance of this, stated with the estimate: 85%); the middle value lies on the limit itself.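

Going by these compounds alone, no step among compound 1, compound 2 and compound 3 can be read in this assay, because all three stand on the same limit: the limit of > 200000 nM in this assay, at which 3 of the 3 values shown sit. The compounds shown leave open whether changing the group on the saturated chain carbon bound to a sulfur affects this assay at all.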